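From piperidin-2-yl to piperidin-3-yl in compound 3

This account rests on a few compounds, and the source may have more. Where it says the series, first, only, none or still open, it means among the compounds named here.

Compound 1 `O=C([C@H]1CCCCN1)N1CCC2(CCN(c3nccc(NCc4ccc(Cl)cc4Cl)n3)CC2)C1`: 172 ug/mL
Compound 2 `O=C([C@@H]1CCCCN1)N1CCC2(CCN(c3nccc(NCc4ccc(Cl)cc4Cl)n3)CC2)C1`: 170 ug/mL

In a physicochemical assay for solubility, read by chemiluminescence, measured as kinetic solubility (a lower number here means a less soluble compound, a higher number a more soluble compound), compound 2 gives 170 ug/mL, and this cannot be told apart from compound 1 at 172 ug/mL. Compound 3 `O=C(C1CCCNC1)N1CCC2(CCN(c3nccc(NCc4ccc(Cl)cc4Cl)n3)CC2)C1` carries piperidin-3-yl in place of piperidin-2-yl on a carbonyl carbon. For the measured compounds named here, the only measured step, a 1.0-fold lower number from compound 1 to compound 2 (0.01 log units; within the scatter), lies within the scatter and rests on (the fact that compounds 1 and 2 differ only in the configuration as drawn), so it tests this new change only loosely. No step beyond the scatter is expected in this assay, though the range stays wide. The estimated change is a 1.0-fold higher number from compound 2 to compound 3 (0.01 log units; within the scatter). For compound 3 the expected value is 175 ug/mL, with an estimated range of 90 ug/mL to 320 ug/mL.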

Compound 3, solubility: 186 ug/mL
Compound 3: the middle estimate sits 1.1-fold (0.03 log units) below what was measured, within the range that was stated.
By their numbers in this assay, from the lowest: compounds 2, 1 and 3 (each within the scatter of the next).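

In this assay, for the compounds shown here, the earlier compounds varied only the drawn configuration at this position, whereas piperidin-3-yl in place of piperidin-2-yl on a carbonyl carbon changes where the ring is joined, giving a 1.1-fold higher number from compound 2 to compound 3 (0.04 log units; within the scatter) and a 1.1-fold higher number from compound 1 to compound 3 (0.03 log units; within the scatter) in this reading. Among these compounds, neither change produces a difference that can be read. Nothing known here explains this result.

All three compounds keep a piperidine on that carbonyl carbon. Going by these compounds, whether a carboxylic acid or an open-chain amine there would move the number beyond the scatter stays open.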